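The compounds below may be only part of what the source reports. "The series", "measured", "known", "first", "only" and "open" are said of these compounds alone.

Measured in a functional assay on PC-3 cells (Homo sapiens) for cytotoxicity, read by MTT assay, with a stated time of 48 h; a higher number here means a weaker inhibitor, a lower number a stronger inhibitor:
compound 1, `CC1=NN(C(=O)c2ccc([N+](=O)[O-])cc2)C(c2ccccc2O)C1`: 36600 nM
compound 2, `CC1=NN(C(=O)COc2ccc(Cl)cc2)C(c2ccccc2O)C1`: 38800 nM
compound 3, `CC1=NN(C(=O)COc2ccc(Cl)cc2)C(c2cc(Br)ccc2O)C1`: 49000 nM

Compound 2 gives a number close to both others; each gap among the three lies within the scatter, so no ranking can be drawn. Compound 4, `CC1=NN(C(=O)CN2CCC(Cl)CC2)C(c2ccccc2O)C1`, is not yet measured. It differs from compound 2 by 4-chloropiperidin-1-yl in place of 4-chlorophenoxy on a saturated chain carbon bound to a carbonyl carbon. Going by the values given here, the only measured step in this assay, a 1.3-fold higher number from compound 2 to compound 3 (0.10 log units; within the scatter), touches an aromatic carbon elsewhere in the molecule and says nothing about the group on the chain carbon. Among the compounds with values here, no measured step bears on this change itself. With all three numbers alike, the step is expected to be a 1.0-fold higher number from compound 2 to compound 4 (0.01 log units; within the scatter), nothing beyond the scatter. Compound 4 is therefore estimated at 40000 nM, expected within 15000 nM to 110000 nM.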

Compound 4, half-maximal inhibitory concentration: 34800 nM
Beside the measured number, compound 4's estimate is 1.1-fold (0.06 log units) above it; measured number inside the range.
By their numbers in this assay, from the lowest: compounds 4, 1, 2 and 3 (each within the scatter of the next).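

In this assay the step to 4-chloropiperidin-1-yl in place of 4-chlorophenoxy on a saturated chain carbon bound to a carbonyl carbon is a 1.1-fold lower number from compound 2 to compound 4 (0.05 log units; within the scatter) for this series. Going by these compounds alone, this is the first direct reading at this position: a non-aromatic ring can stand in place of the aromatic ring of carbon only with no step beyond the scatter. No supporting measurement is available to explain this result.

Open, as far as these compounds go, is how an unsubstituted piperidin-1-yl, a dimethylamino group or a carboxylic acid on this chain carbon would read. Also open, from the compounds shown here alone, is whether bromo on the aromatic carbon gives a similar reading with 4-chloropiperidin-1-yl present.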